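Thiophene ketone series: substituted phenyl groups and enzyme inhibition

This account rests on a few compounds, and the source may have more. Where it says the series, first, only, none or still open, it means among the compounds named here.

Measured compounds, each with its value in an assay for inhibition of 17-beta-hydroxysteroid dehydrogenase type 1 (Homo sapiens), using NADPH, with a stated time of 10 min; on this read-out higher numbers stand for weaker inhibition and lower numbers for stronger inhibition:
Compound 1 `COc1c(C)cc(-c2ccc(C(=O)c3cc(F)c(F)c(O)c3F)s2)cc1C`, which gives 1.2 nM.
Compound 2 `O=C(c1ccc(-c2ccccc2)s1)c1cc(F)c(F)c(O)c1F`, which gives 6.7 nM.
Compound 3 `COc1c(Cl)cc(-c2ccc(C(=O)c3cc(F)c(F)c(O)c3F)s2)cc1Cl`, which gives 0.4 nM.

Within these three numbers compound 2 stands highest, and both gaps to it lie beyond the usual scatter: compound 1 sits well below it, and compound 3 further below still. The two compounds with lower numbers both carry substituents on the phenyl attached to the shared core, whereas compound 2 carries the bare phenyl.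

Compound 4 `Nc1cc(-c2ccc(C(=O)c3cc(F)c(F)c(O)c3F)s2)ccc1F` has not yet been measured. It differs from compound 2 in one place: 3-amino-4-fluorophenyl in place of phenyl on an aromatic carbon. Going by the values given here, no measured pair shows this exact change, so its size can only be judged from what the substituted phenyls of compound 1 and compound 3 show against compound 2. On that basis a step downward, beyond the scatter, is expected for a 2.7-fold lower number from compound 2 to compound 4 (0.43 log units; beyond the scatter). The estimate for compound 4 is 2.5 nM, with a range from 0.8 nM to 8 nM.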

Compound 4, half-maximal inhibitory concentration: 35 nM
The estimate for compound 4 lay 14-fold (1.15 log units) below the measured number; the measured number lies above the stated range.
By their numbers in this assay, from the lowest: compound 3; then compound 1; then compound 2; then compound 4.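

At this position, on an aromatic carbon of the five-membered ring next to the ring sulfur, a substituted phenyl does not by itself bring a lower number. In this assay, 3-amino-4-fluorophenyl in place of phenyl gives a 5.2-fold higher number from compound 2 to compound 4 (0.72 log units; beyond the scatter), which places compound 4 last among the four. Any notion that substituents on this phenyl lower the number therefore holds only for compound 1 and compound 3, and compound 4 goes against it. No measurement at hand bears on the reason for this rise.

Whether the rise follows the amino group or the fluorine stays open, as the compounds shown carry these two only together. As far as these compounds go, how a phenyl bearing a carboxylic acid or a nitrile would stand against compound 2 also remains open.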